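A few compounds are considered here, and "the series" means these few. Any claim that something is new, unique, unknown or untested is made for them only; others in the source may bear on it.

Of the compounds shown here, three have been measured in a functional assay on RXF 393 cells (Homo sapiens) for cytotoxicity, read by sulforhodamine B assay, with a stated time of 48 h; on this read-out higher numbers stand for weaker inhibition of growth and lower numbers for stronger inhibition of growth. Compound 3 `ClCc1cccc(Cn2cnc3nc(Cl)nc(Cl)c32)c1` gives 1340 nM, compound 2 `ClCc1ccc(Cn2cnc3nc(Cl)nc(Cl)c32)cc1` gives 1650 nM, and compound 1 `ClCc1cccc(Cn2cnc3ncnc(Cl)c32)c1` gives 2040 nM. Compound 1 differs from compound 3 by hydrogen in place of chloro on an aromatic carbon, and the resulting step, a 1.5-fold higher number from compound 3 to compound 1 (0.18 log units; within the scatter), lies within the scatter. The difference between the core of compound 2 and the core of compound 3 is not broken down here; their two values in this assay lie within the scatter of each other.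

Compound 4 `ClCc1ccc(Cn2cnc3ncnc(Cl)c32)cc1` has not yet been measured in this assay. It differs from compound 2 by hydrogen in place of chloro on an aromatic carbon, the same change as that from compound 3 to compound 1, at a place described in the same words. The expected step is a 1.5-fold higher number from compound 2 to compound 4 (0.18 log units; within the scatter), set beside the earlier 1.5-fold higher number from compound 3 to compound 1 (0.18 log units; within the scatter). That expectation rests on compound 2 at 1650 nM and on the size of the measured step from compound 3 to compound 1, which was within the scatter. For compound 4 the estimated value in this assay is 2500 nM, with a range from 1200 nM to 5000 nM.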

Compound 4, concentration for 50% growth inhibition: 1650 nM
Compound 4: middle estimate off by 1.5-fold (0.18 log units), on the high side; the measured number falls inside the stated range.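

In this assay hydrogen in place of chloro on an aromatic carbon gives no change at the digits printed from compound 2 to compound 4 (within the scatter) on this second pair of compounds. Set beside the earlier step, the change reads alike on the two cores: the same change on two cores in this assay, a 1.5-fold higher number (0.18 log units; within the scatter) from compound 3 to compound 1 and no change at the digits printed (within the scatter) from compound 2 to compound 4, 1.5-fold (0.18 log units) apart, within the scatter of two such steps

Among these compounds, this shows only that the change carries from one core to the other here with no gap beyond the scatter; it does not show that the chloro group matters or does not matter for growth inhibition, since neither step can be told from repeat scatter, and two cores make no rule for the series.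

The compounds shown leave open whether another group on that aromatic carbon, such as an amine or a methoxy group, would move the number beyond the scatter. They also leave open whether the same change keeps its size on a core carrying a carboxylic acid or a longer chain.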